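A few compounds are considered here, and "the series" means these few. Any claim that something is new, unique, unknown or untested is made for them only; others in the source may bear on it.

Of the compounds shown here, two built on a shared core have been tested so far. In a functional assay on DU-145 cells (Homo sapiens) for cytotoxicity, read by trypan blue exclusion, with a stated time of 96 h (on this read-out higher numbers stand for weaker inhibition and lower numbers for stronger inhibition), compound 1 (`COc1ccc(/C=C/S(=O)(=O)Cc2ccc(OC)c(N)c2)c(OC)c1`) gives 500 nM and compound 2 (`COc1ccc(OC)c(/C=C/S(=O)(=O)Cc2ccc(OC)c(N)c2)c1`) gives 750 nM as its reading. Compound 2 therefore stands level with compound 1, since the gap between these two numbers lies within the ordinary scatter of repeated measurements. Two such readings give a starting level but no trend.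

Compound 3 (`COc1ccc(CS(=O)(=O)/C=C/c2cc(OC)c(OC)cc2OC)cc1N`) is the next one to consider. It is reached from compound 2 by a single edit, methoxy in place of hydrogen on an aromatic carbon, and the rest of the structure stays the same. Among the compounds with values here, no measured pair here differs in one place, so the data do not yet show what an added methoxy does in this assay on these compounds. The expectation therefore stays close to the two known readings, leaning only modestly toward stronger inhibition. The estimated change is a 1.9-fold lower number from compound 2 to compound 3 (0.27 log units; within the scatter) and is expected to be small. For compound 3 the expected value is 400 nM with an estimated range from 80 nM to 1500 nM in all.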

Compound 3, half-maximal inhibitory concentration: 250 nM
Compound 3: the middle estimate sits 1.6-fold (0.20 log units) above what was measured; measured number inside the range.
By their numbers in this assay, from the lowest: compounds 3, 1 and 2 (each within the scatter of the next, the first and the last beyond it).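

Within the data shown here, this is the first single-place change that can be read in this assay: placing a methoxy on the aromatic carbon ortho to a methoxy group, meta to a methoxy group and para to a large group gives a 3.0-fold lower number from compound 2 to compound 3 (0.48 log units; beyond the scatter), so this added group is tolerated here and goes with stronger inhibition. The same kind of edit gives a 2.0-fold lower number from compound 1 to compound 3 (0.30 log units; within the scatter), so the effect does not clearly show up from both starting points, and the clear change rests on a single pair. Nothing measured here explains the difference seen with this added methoxy.

The compounds shown leave open whether the result is specific to methoxy or whether other groups on the same aromatic carbon, such as a hydroxyl, a fluorine or the slightly longer ethoxy, would give similar numbers. They also cannot say whether the lower number from this edit would hold if the amine elsewhere in the structure were replaced, for example by a hydroxyl.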